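Aryl swap repeated on a second core: cytotoxicity notes

This account rests on a few compounds, and the source may have more. Where it says the series, first, only, none or still open, it means among the compounds named here.

Compound 1 `COc1ccc(N2CCN(C(=S)SCc3nc4cc(Cl)c(Cl)cc4[nH]3)CC2)cc1` is the reference point of this set. In a functional assay on MCF7 cells (Homo sapiens) for cytotoxicity, read by MTT assay, with a stated time of 24 h (on this read-out lower numbers stand for stronger inhibition and higher numbers for weaker inhibition), compound 1 gives 19900 nM. Compound 2 `S=C(SCc1nc2cc(Cl)c(Cl)cc2[nH]1)N1CCN(c2ccccc2Cl)CC1` carries one change relative to compound 1, (2-chlorophenyl in place of 4-methoxyphenyl on an amine nitrogen in a ring), and in this assay compound 2 gives 60200 nM. The step of a 3.0-fold higher number from compound 1 to compound 2 (0.48 log units; beyond the scatter) is the only measured effect of that change so far. Compound 3 `COc1ccc(N2CCN(C(=S)SCc3nc4cc(C)c(C)cc4[nH]3)CC2)cc1` is built on a second core; how it differs from the core of compound 1 is not broken down here. In this assay compound 3 gives 46000 nM, a number within the scatter of compound 2 and beyond the scatter from compound 1. Compound 4 `Cc1cc2nc(CSC(=S)N3CCN(c4ccccc4Cl)CC3)[nH]c2cc1C` is not yet measured. It differs from compound 3 by 2-chlorophenyl in place of 4-methoxyphenyl on an amine nitrogen in a ring, the same change at the same place as that from compound 1 to compound 2. The expectation for compound 4 rests on a single prior instance, the step of a 3.0-fold higher number from compound 1 to compound 2 (0.48 log units; beyond the scatter), and is correspondingly thin. For compound 4 the step of a 2.8-fold higher number from compound 3 to compound 4 (0.45 log units; beyond the scatter) is expected, carried over from that one measured instance. Compound 4 is therefore estimated at 130000 nM in this assay. The expected range for compound 4 runs from 55000 nM to 300000 nM. A number this weak may also come back only as a limit of the assay.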

Compound 4, half-maximal inhibitory concentration: 8390 nM
Compound 4: middle estimate off by 15-fold (1.19 log units), on the high side; measured number below the stated range.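

In this assay, 2-chlorophenyl in place of 4-methoxyphenyl gives a 5.5-fold lower number from compound 3 to compound 4 (0.74 log units; beyond the scatter), so on this second core the change runs opposite to its direction on the core of compound 1, and a step measured on one core cannot be carried to the other in this series. The two steps set side by side read: the same change on two cores in this assay, a 3.0-fold higher number (0.48 log units; beyond the scatter) from compound 1 to compound 2 and a 5.5-fold lower number (0.74 log units; beyond the scatter) from compound 3 to compound 4, 17-fold (1.22 log units) apart, beyond the scatter of two such steps. This shows that the effect of the aryl swap depends on the core for these two pairs, but it does not show what in the cores produces the reversal, nor whether either direction would hold on any further core.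

The compounds shown leave open whether the reversal is specific to this pair of aryl groups or would also appear with an unsubstituted phenyl or a 4-fluorophenyl on the same ring nitrogen. They also leave open how an amine or a carboxylic acid on the aryl ring would behave on each of the two cores.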